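Adding Methylcarbamoyl to Compound 2

The source may hold more compounds than are shown below. What is called first, only, known or untested is meant among the compounds shown, and "the series" means these compounds.

Compound 1 `C=C(C)C(=O)Nc1cccc(CNc2nc(Nc3cnn(CCOC)c3)ncc2Cl)c1` gives 0.035 h
Compound 2 `C=CC(=O)Nc1ccc(CNc2nc(Nc3cnn(C)c3)ncc2Cl)cc1` gives 0.0517 h

Within the data shown here, in an ADME assay (liver, Mus musculus) for metabolic stability, using microsomes (a lower number here means that the compound disappears faster, a higher number that the compound lasts longer), compound 2 stands at 0.0517 h and thus within the scatter of compound 1, the only other measured compound. Both half-lives are short, and the two structures differ in more than one place. The next compound, compound 3 `C=CC(=O)Nc1ccc(CNc2nc(Nc3cnn(CC(=O)NC)c3)ncc2Cl)cc1`, has not yet been measured. Among the measured compounds shown here, it keeps the acrylamide-bearing frame of compound 2 and carries methylcarbamoyl in place of hydrogen on a saturated chain carbon bound to an aromatic nitrogen as its only change. For the measured compounds named here, no measured pair shows a change of this kind, so the data offer no direct guide to its size. The estimate therefore starts from compound 2 at 0.0517 h as its anchor. The expected result is a 1.0-fold lower number from compound 2 to compound 3 (0.01 log units; within the scatter) and so no change beyond the scatter in either direction. Compound 3 is expected at 0.05 h (estimated range 0.025 h to 0.1 h).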

Compound 3, half-life: 0.355 h
Compound 3: middle estimate off by 7.1-fold (0.85 log units), on the low side; measured number outside the range, above it.
By their numbers in this assay, from the lowest: compounds 1 and 2 (each within the scatter of the next); then compound 3.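

In this assay, methylcarbamoyl in place of hydrogen on a saturated chain carbon bound to an aromatic nitrogen gives a 6.9-fold higher number from compound 2 to compound 3 (0.84 log units; beyond the scatter). Among these compounds, this is the first step that changes one place only, and it shows that the half-life responds to a change at this position, with the compound lasting longer once methylcarbamoyl is present. Nothing shown here gives a reason for the size or direction of this step.

A single step cannot tell whether the longer half-life goes with the whole methylcarbamoyl group or with only a part of it, such as the carbonyl or the amide hydrogen. From the compounds shown here alone, it also remains open how a dimethylcarbamoyl group, a carboxylic acid, an amine or a longer chain at the same place would compare, or whether the step carries over to other frames.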